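Swapping the Aryl Group on the Carbonyl Carbon

The source may hold more compounds than are shown below. What is called first, only, known or untested is meant among the compounds shown, and "the series" means these compounds.

Two compounds of this set have been run in a functional assay on NCI-H23 cells (Homo sapiens) for inhibition, read by sulforhodamine B assay, with a stated time of 48 h; on this read-out lower numbers stand for stronger inhibition of growth and higher numbers for weaker inhibition of growth. Compound 1 `COc1ccc(-c2cc(/C=C/C(=O)c3ccc(N)cc3)[nH]n2)cc1` gives 13100 nM. Compound 2 `COc1cc(-c2cc(/C=C/C(=O)c3ccc(Cl)c(Cl)c3)[nH]n2)cc(OC)c1OC` reaches only a limit of the assay, > 100000 nM, so its place is known just as the limit of > 100000 nM in this assay, at which 1 of the 2 values shown sits, and no number stands behind it. Compound 3 `COc1ccc(C(=O)/C=C/c2cc(-c3cc(OC)c(OC)c(OC)c3)n[nH]2)cc1` differs from compound 2 in a single spot: 4-methoxyphenyl in place of 3,4-dichlorophenyl on a carbonyl carbon. Among the compounds with values here, no measured pair in this set shows that exchange, and with compound 2 sitting at a limit the step has no measured size to lean on. Compound 3 is expected to remain a weak inhibitor, with a step of an at least 1.6-fold lower number from compound 2 to compound 3 (0.22 log units; that floor lies within the scatter) in this assay that stays within or little beyond the usual scatter. The estimate for compound 3 in this assay is 60000 nM, with a range from 15000 nM to 100000 nM.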

Compound 3, concentration for total growth inhibition: 12200 nM
The estimate for compound 3 lay 4.9-fold (0.69 log units) above the measured number; measured number outside the range, below it.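

At this position the aryl group does matter in this assay: 4-methoxyphenyl in place of 3,4-dichlorophenyl on the carbonyl carbon brings an at least 8.1-fold lower number from compound 2 to compound 3 (0.91 log units; beyond the scatter). Within the data shown here, this is the first one-place comparison in the set, and it shows that the change alone moves the read-out beyond the scatter. Compound 2 stands only at a limit of the assay, so the step has a floor and no exact size: the limit of > 100000 nM in this assay, at which 1 of the 3 values shown sits.

The compounds shown do not separate the loss of the two chlorine atoms from the gain of the methoxy group. No pair shown makes one of these changes without the other. They also leave open whether 4-chlorophenyl or 4-hydroxyphenyl on the same carbonyl carbon would read like compound 3 or stay at the limit like compound 2.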